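The compounds below may be only part of what the source reports. "The series", "measured", "known", "first", "only" and "open" are said of these compounds alone.

Of the compounds shown here, three sharing one core have so far been tested in a functional assay on BJAB cells (Homo sapiens) for antiproliferative activity, with a stated time of 4 days; a higher number here means that more compound is needed for the effect, a lower number that less compound is needed. Compound 1 `COc1cncc(-c2c(C)nn(-c3nc(-c4ccc(Cl)c(Cl)c4)c(SC(C)C)s3)c2C(=O)O)c1` gives 21000 nM. Compound 2 `Cc1nn(-c2nc(-c3ccc(Cl)c(Cl)c3)c(SC(C)C)s2)c(C(=O)O)c1-c1cccc(C(F)(F)F)c1` gives 22000 nM, which is the highest of the three numbers, although its nearest neighbour is compound 1 and the difference, a 1.0-fold higher number from compound 1 to compound 2 (0.02 log units; within the scatter), means the pair cannot be told apart. Compound 3 `Cc1nn(-c2nc(-c3ccc(Cl)c(Cl)c3)c(SC(C)C)s2)c(C(=O)O)c1-c1cc(C(F)(F)F)cc(C(F)(F)F)c1` gives 1800 nM, and the step of a 12-fold lower number from compound 2 to compound 3 (1.09 log units; beyond the scatter) is the only clear movement seen among these measurements.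

Compound 4 `Cc1nn(-c2nc(-c3ccc(Cl)c(Cl)c3)c(SC(C)C)s2)c(C(=O)O)c1-c1ccccc1Cl` has not yet been measured. It differs from compound 2 in one place: 2-chlorophenyl in place of 3-(trifluoromethyl)phenyl on an aromatic carbon.

Among the compounds with values here, no measured step makes exactly this exchange, so the estimate rests on analogy. Swapping one aromatic group for another, as from compound 1 to compound 2, left the number unchanged, whereas adding a trifluoromethyl group, as from compound 2 to compound 3, lowered it sharply. Compound 4 carries a smaller group without any trifluoromethyl, so in this assay compound 4 is expected to give about 25000 nM, somewhere between 8000 nM and 80000 nM. The expected step of a 1.1-fold higher number from compound 2 to compound 4 (0.06 log units; within the scatter) is thus estimated to stay within the scatter, with no clear gain anticipated.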

Compound 4, half-maximal effective concentration: 13100 nM
The estimate for compound 4 lay 1.9-fold (0.28 log units) above the measured number, and the stated range covers the measured number.
By their numbers in this assay, from the lowest: compound 3; then compounds 4, 1 and 2 (each within the scatter of the next).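

In this assay, the place on the five-membered aromatic ring with 2 nitrogen now also holds 2-chlorophenyl, and neither exchange moves the number beyond the scatter: there is a 1.7-fold lower number from compound 2 to compound 4 (0.23 log units; within the scatter) for the swap from 3-(trifluoromethyl)phenyl and a 1.6-fold lower number from compound 1 to compound 4 (0.20 log units; within the scatter) for the swap from 5-methoxypyridin-3-yl. Within the data shown here, a chlorine on a carbon-only ring, in a group with fewer heavy atoms than 3-(trifluoromethyl)phenyl, therefore gives a result that cannot be told apart from those of the two earlier groups, so compounds 1, 2 and 4 form one cluster, and the only clear step remains the one to compound 3. Nothing available bears on why these three compounds sit so close together.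

The exchange from compound 2 to compound 4 changes both the substituent and the numbered place it occupies on the phenyl ring, so the effect of each alone stays unresolved. Also open, as far as these compounds go, is how a plain phenyl group, or a phenyl ring carrying an amine or a carboxylic acid, would behave at this place.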